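The source may hold more compounds than are shown below. What is called first, only, known or untested is meant among the compounds shown, and "the series" means these compounds.

Measured in an ADME assay on L6 cells (Rattus norvegicus) for cytotoxicity; a higher number here means a weaker inhibitor, a lower number a stronger inhibitor:
- Compound 1 `O=C(CN1CCCC1)OC1CC2(N3CCCCC3)CC(c3ccccc3)C1C(c1ccccc1)C2`: 16400 nM; 52000 nM (2 entries)
- Compound 2 `O=C(CCN1CCCCC1)OC1CC2(N3CCCC3)CC(c3ccccc3)C1C(c1ccccc1)C2`: 17800 nM

In this assay compound 2 stands at 17800 nM, the only number shown for it, and one further entry for it gives no single number. Repeat entries for one compound can lie well apart, as seen in the several entries of compound 1 in this assay, 16400 nM; 52000 nM (2 entries).

Compound 3 `O=C(CCN1CCCCC1)OC1CC2(N3CCCCC3)CC(c3ccccc3)C1C(c1ccccc1)C2` differs from compound 2 at one place, with piperidin-1-yl in place of pyrrolidin-1-yl on a saturated ring carbon. Among the measured compounds shown here, no measured pair shows this change on its own, so the expectation has little to rest on. No step beyond the scatter is expected in this assay, and neither direction is favoured. This expectation starts from compound 2 at 17800 nM and takes its width from the spread in the several entries of compound 1 in this assay, 16400 nM; 52000 nM (2 entries). The estimated 1.1-fold higher number from compound 2 to compound 3 (0.05 log units; within the scatter) stays within the scatter. Compound 3 is expected at about 20000 nM. The estimated range for compound 3 runs from 8000 nM to 50000 nM.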

Compound 3, half-maximal inhibitory concentration: 54600 nM
Estimate against measurement, compound 3: 2.7-fold (0.44 log units) below, outside the stated range (above it).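

Among the compounds shown here, with this assay as the read-out, the first pair that isolates this position gives a 3.1-fold higher number from compound 2 to compound 3 (0.49 log units; beyond the scatter), so piperidin-1-yl is the weaker inhibitor of the two in this pair. The earlier compounds shown here held no such pair, and this result shows that the amine ring on this saturated ring carbon cannot be treated as interchangeable, at least with the ((2-(piperidin-1-yl)ethyl)carbonyl)oxy group in place. The step still rests on one pair and should be read with care, since repeat entries for a single compound in this assay can lie well apart: the several entries of compound 1 in this assay, 16400 nM; 52000 nM (2 entries)

The compounds shown leave open whether the same change gives a similar step alongside a different ester side chain, such as the shorter pyrrolidin-1-yl chain of compound 1. They also leave open whether the trend continues to a larger ring such as azepan-1-yl, and how a ring with oxygen such as morpholin-4-yl or an open-chain amine such as dimethylamino would behave on this ring carbon.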